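This account rests on a few compounds, and the source may have more. Where it says the series, first, only, none or still open, it means among the compounds named here.

Working notes on the series. Two compounds carry numbers in a functional assay on CHO cells for antagonist activity at prostaglandin E2 receptor EP3 subtype (Homo sapiens), read by cAMP accumulation; a higher number here means a weaker inhibitor, a lower number a stronger inhibitor. Compound 1 `CCn1ncc2c(F)cc(-c3ccc(C(CC)(CC)c4nnc(C)[nH]4)c(=O)[nH]3)cc21` gives 90 nM in this assay. Compound 2 `CC(C)C(/C=C1\CCNC1=O)c1ccc(-c2ccc3cccc(F)c3c2)[nH]c1=O` gives 8.7 nM in this assay, the lower of the two numbers, and its gap to compound 1 lies beyond the scatter of repeated measurements.

Compound 3 `CC(C)C(Cc1noc(=O)[nH]1)c1ccc(-c2ccc3cccc(F)c3c2)[nH]c1=O` is not yet measured. It differs from compound 2 in one place: a group of 7 heavy atoms (3 carbon, 2 nitrogen, 2 oxygen; one five-membered aromatic ring with 3 hetero atoms) in place of a group of 7 heavy atoms (5 carbon, 1 nitrogen, 1 oxygen; one five-membered non-aromatic ring with 1 hetero atom), on a saturated chain carbon bound to an aromatic carbon and a saturated chain carbon. For the measured compounds named here, no pair of measured compounds carries this change, so there is no measured step to lean on; compound 1 shares only its unrelated core and is no guide here. With nothing measured for this change, the expected step in this assay is small, toward a higher number, and not clearly beyond the scatter: the estimated step is a 2.3-fold higher number from compound 2 to compound 3 (0.36 log units; beyond the scatter). Compound 3 is expected to give about 20 nM in this assay, with a range from 5 nM to 80 nM.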

Compound 3, half-maximal inhibitory concentration: 70 nM
The estimate for compound 3 lay 3.5-fold (0.54 log units) below the measured number, and the stated range covers the measured number.
By their numbers in this assay, from the lowest: compound 2; then compounds 3 and 1 (each within the scatter of the next).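

For the compounds shown here, at the saturated chain carbon bound to an aromatic carbon and a saturated chain carbon, this is the first measured change, and in this assay the position proves sensitive to the group it carries: the swap gives an 8.0-fold higher number from compound 2 to compound 3 (0.91 log units; beyond the scatter). The two groups match in heavy atoms and hydrogen-bond donors, so that match alone does not keep the number in place; they differ in ring type, in double bonds outside aromatic rings and in hydrogen-bond acceptors. No measurement shown bears on the reason for this step.

A single step cannot separate the contributions of the ring and the acceptors. Going by these compounds, whether a carboxylic acid or a primary amide at this position would give a number nearer that of compound 2 remains open.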